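Taking one hydroxy from the ring of compound 2

The compounds below may be only part of what the source reports. "The series", "measured", "known", "first", "only" and "open" are said of these compounds alone.

Of the compounds shown here, three sharing one core have been measured in a functional assay on A549 cells (Homo sapiens) for cytotoxicity, read by MTT assay, with a stated time of 72 h; on this read-out lower numbers stand for stronger inhibition and higher numbers for weaker inhibition. Compound 1 `CN(C)CCCCCn1c2c(c3ccccc31)C(=O)c1c[n+]([O-])c3ccccc3c1C2=O` gives 210 nM, and compound 3 `O=C1c2c[n+]([O-])c3ccccc3c2C(=O)c2c1c1ccccc1n2CCCCn1ccnc1` gives 170 nM. Compound 2 `O=C1c2c[n+]([O-])c3ccccc3c2C(=O)c2c1c1ccccc1n2Cc1cn([C@H]2O[C@H](CO)[C@@H](O)[C@H]2O)nn1` gives 2680 nM, the highest number of the three and the weakest inhibition, beyond the scatter from both others.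

Compound 4 `O=C1c2c[n+]([O-])c3ccccc3c2C(=O)c2c1c1ccccc1n2Cc1cn([C@@H]2C[C@H](O)[C@@H](CO)O2)nn1` differs from compound 2 in one place: hydrogen in place of hydroxy on a saturated ring carbon. In short, it has hydrogen in place of hydroxy on a saturated ring carbon. Going by the values given here, the only measured step between two compounds that differ in one place is a 1.2-fold lower number from compound 1 to compound 3 (0.09 log units; within the scatter). That step swaps a group on a saturated chain, not on this ring, so it is only a weak guide, and no measurement shows what this ring change does. A small change is therefore the cautious expectation in this assay, with no shift beyond the scatter in either direction. The estimated step is a 1.2-fold lower number from compound 2 to compound 4 (0.09 log units; within the scatter). The expected value for compound 4 is 2200 nM, within an estimated range of 700 nM to 6000 nM.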

Compound 4, half-maximal inhibitory concentration: 120 nM
Compound 4: middle estimate off by 18-fold (1.26 log units), on the high side; the whole stated range lies above it.
By their numbers in this assay, from the lowest: compounds 4, 3 and 1 (each within the scatter of the next); then compound 2.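

In this assay, going by these compounds alone, the step is a 22-fold lower number from compound 2 to compound 4 (1.35 log units; beyond the scatter), so a single hydroxy on this saturated ring carbon, next to the ring atom that bears the large group, carries far more weight than the earlier compounds could reveal. This position is sensitive: replacing hydroxy with hydrogen removes just one heavy atom, yet the step lies well beyond the scatter. Nothing shown gives a reason for this large drop in the number.

Going by these compounds, it remains open whether the mere absence of the hydroxy matters, or whether a fluorine or a methoxy group on the same carbon would give a similar number. The compounds shown also leave open whether removing the hydroxy that remains on this ring, or the hydroxymethyl group, would move the number as sharply.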